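The source may report more compounds than this note shows. Statements on the series, on what has been measured and on what is new or still open speak of the compounds shown alone.

Compound 2 `COc1nc2ccc(Br)cc2cc1C(c1ccccc1)n1cc(CCO)nn1` and compound 1 `COc1nc2ccc(Br)cc2cc1C(c1ccccc1)n1cc(-c2ccc(Br)cc2)nn1` share a core and differ only in the group on the five-membered aromatic ring. In an ADME assay on HEK293 cells (Homo sapiens) for cytotoxicity, read by sulforhodamine B assay, with a stated time of 48 h, tested at 10 uM (a higher number here means more inhibition at the concentration tested (going by the name of the read-out), a lower number less inhibition), compound 1 gives 6.28%, and compound 2 gives 4.54%. Compound 2 stands alongside compound 1 on these numbers, the gap between the two lying within the scatter, so neither can be called weaker or stronger than the other. Going by the values given here, the step of a number 1.7 percentage points lower from compound 1 to compound 2 (within the scatter) is the only measured step here and it stays within the scatter.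

Compound 3 `COc1nc2ccc(Br)cc2cc1C(c1ccccc1)n1cc(-c2ccccc2C(F)(F)F)nn1` takes the step from compound 2 by 2-(trifluoromethyl)phenyl in place of 2-hydroxyethyl on an aromatic carbon. Among the compounds with values here, the one measured step that bears on it is the exchange of 4-bromophenyl for 2-hydroxyethyl at the same place, which moved the number by a number 1.7 percentage points lower from compound 1 to compound 2 (within the scatter); putting an aryl group back at that position in compound 3 is therefore expected to shift this assay by at most a small amount, a step of about a number 1.5 percentage points higher from compound 2 to compound 3 (within the scatter), which is not beyond the scatter. For compound 3 the number in this assay is estimated at 6%, with a range from -4% to 18%.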

Compound 3, a percentage reported as inhibition, at one concentration (the size of the read-out at that concentration, not a potency): 14.3%
Compound 3: middle estimate off by 8.3 percentage points, on the low side; measured number inside the range.
By their numbers in this assay, from the lowest: compounds 2, 1 and 3 (each within the scatter of the next).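

Across the three groups now seen at this place, on an aromatic carbon of a five-membered aromatic ring with 3 nitrogen, the readings in this assay still cannot be told apart. Putting 2-(trifluoromethyl)phenyl in place of 2-hydroxyethyl gives a number 9.8 percentage points higher from compound 2 to compound 3 (within the scatter), and putting it in place of 4-bromophenyl gives a number 8 percentage points higher from compound 1 to compound 3 (within the scatter). So the exchange of a chain without a ring for a group of 10 heavy atoms with a six-membered aromatic ring, and the exchange of one substituted phenyl group for another, both stay inside the scatter, and nothing available speaks to the cause of the small differences seen.

The compounds shown leave open whether any group at this place can move the reading in this assay beyond the scatter, for instance an amine, a carboxylic acid or a longer chain. They also leave open whether a change elsewhere on the shared core, rather than on this carbon, would do so.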